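Hydrazone series: aryl swap on the shorter-chain amide

The compounds below may be only part of what the source reports. "The series", "measured", "known", "first", "only" and "open" are said of these compounds alone.

Measured so far:
compound 1 `O=C(CCc1nc2ccccc2c(=O)[nH]1)N/N=C/c1ccc(O)c(O)c1` — 113000000 nM
compound 2 `COc1ccc(/C=N/NC(=O)CCCc2nc3ccccc3c(=O)[nH]2)cc1` — 247000000 nM

In a physicochemical assay, read by spectrophotometry, with a stated time of 30 min (on this read-out higher numbers stand for weaker inhibition and lower numbers for stronger inhibition), compound 1 gives 113000000 nM, the lowest of the two numbers recorded; compound 2 gives 247000000 nM, a higher number, and the gap between them lies beyond the scatter. Within the data shown here, no single-change step between measured compounds is available, so the whole picture rests on these two values.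

Compound 3 `COc1ccc(/C=N/NC(=O)CCc2nc3ccccc3c(=O)[nH]2)cc1` is not yet measured. It follows from compound 1 by one change: 4-methoxyphenyl in place of 3,4-dihydroxyphenyl on a carbon with a double bond to nitrogen

On the numbers shown, the only other compound, compound 2, which also carries the 4-methoxyphenyl group, sits above compound 1. Compound 3 is therefore expected to move in the same direction, towards a higher number and weaker inhibition, with the step of a 1.9-fold higher number from compound 1 to compound 3 (0.29 log units; within the scatter) expected to be modest, near the edge of the scatter rather than far beyond it. For compound 3 the expected value in this assay is 220000000 nM, within a range from 100000000 nM to 500000000 nM.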

Compound 3, half-maximal inhibitory concentration: 214000000 nM
Compound 3: the middle estimate sits 1.0-fold (0.01 log units) above what was measured, and the stated range covers the measured number.
By their numbers in this assay, from the lowest: compounds 1, 3 and 2 (each within the scatter of the next, the first and the last beyond it).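

In this assay, this position now has its first single-change step, which gives a 1.9-fold higher number from compound 1 to compound 3 (0.28 log units; within the scatter) when 4-methoxyphenyl replaces 3,4-dihydroxyphenyl on a carbon with a double bond to nitrogen. The read-out therefore does not separate the two groups, even though 2 hydrogen-bond donors and 2 hydrogen-bond acceptors give way to 0 hydrogen-bond donors and 1 hydrogen-bond acceptor at 8 heavy atoms on each side. No measurement on hand bears on why the two groups read alike in this series.

Whether this tolerance extends to other kinds of group remains open, since the compounds shown offer no way to tell how an aminophenyl or carboxyphenyl group, or an unsubstituted phenyl ring, would read on the same carbon. As far as these compounds go, it also remains open whether the 3,4-dihydroxyphenyl group would read the same on the longer chain of compound 2, and whether a single hydroxyl on the aromatic ring would fall within the scatter of either group seen so far.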